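The source may hold more compounds than are shown below. What is called first, only, known or untested is meant among the compounds shown, and "the series" means these compounds.

Compound 1 `Nc1ccc(-c2nc3ccccc3s2)cc1CO`: in a functional assay on MCF7 cells (Homo sapiens) for cytotoxicity (on this read-out lower numbers stand for stronger inhibition and higher numbers for weaker inhibition), compound 1 gives 6 nM.
Compound 2 `Nc1ccc(-c2nc3c(O)cccc3s2)cc1`: compound 2 gives > 100000 nM, which is a limit of this assay.
Compound 3 `CC(=O)ON(C(C)=O)c1ccc(-c2nc3ccccc3s2)cc1`: compound 3 gives < 1 nM, likewise a limit.

Compound 2 stands at the weak end of the three values, at the limit of > 100000 nM in this assay, at which 1 of the 3 values shown sits, while compound 3 sits at the limit of < 1 nM in this assay, at which 1 of the 3 values shown sits, and only compound 1 gives a number between them. For the measured compounds named here, no step between two measured compounds is available, so the values of compound 1 and compound 3 say only where each stands next to compound 2.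

Compound 4 `Cc1cc(-c2nc3c(O)cccc3s2)ccc1N` is not yet measured. It differs from compound 2 by methyl in place of hydrogen on an aromatic carbon. With compound 2 at a limit, a methyl of this kind offers no ground to expect a move beyond the scatter; the expected step is a number no higher from compound 2 to compound 4 (the limit leaves the size open), in this assay. Compound 4 is therefore estimated at 100000 nM, within 10000 nM to 1000000 nM.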

Compound 4, half-maximal inhibitory concentration: > 100000 nM
Compound 4: a limit, no number; the forecaster's own chance of this, stated with the estimate: 75%; the middle value lies on the limit itself.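

In this assay compound 2 and compound 4 both stand at a limit, so no step between them can be read: the limit of > 100000 nM in this assay, at which 2 of the 4 values shown sit.

Going by these compounds, whether methyl in place of hydrogen on an aromatic carbon changes the activity of compound 2 at all stays open.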